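Acetyl in place of chloro on a leukotriene antagonist core

This account rests on a few compounds, and the source may have more. Where it says the series, first, only, none or still open, it means among the compounds named here.

Measured so far:
compound 1, `CCC(CC)(CC(=O)Nc1cccc(OCc2ccc3ccc(Cl)cc3n2)c1)C(=O)O`: 0.8 nM
compound 2, `CCC(CC)(CC(=O)Nc1cccc(OCc2ccc3cc(C)ccc3n2)c1)C(=O)O`: 24 nM

Of the compounds shown here, two have been measured in a functional assay on ileum (Cavia porcellus) for antagonist activity at cysteinyl leukotriene receptor (Homo sapiens); on this read-out lower numbers stand for stronger inhibition and higher numbers for weaker inhibition. Compound 1 gives 0.8 nM, the lower of the two numbers; compound 2 gives 24 nM, a gap that lies beyond the scatter. Compound 3, `CCC(CC)(CC(=O)Nc1cccc(OCc2ccc3ccc(C(C)=O)cc3n2)c1)C(=O)O`, is not yet measured. It differs from compound 1 in one place: acetyl in place of chloro on an aromatic carbon. Among the measured compounds shown here, no pair of measured compounds differs in exactly this way, so no direct step for this change is available; compound 2, which carries a methyl rather than a chloro, shows only that a change on the fused ring system can move the number well beyond the scatter. For compound 3 a modest loss is expected, the step of a 3.8-fold higher number from compound 1 to compound 3 (0.57 log units; beyond the scatter) being an estimate rather than a reading. Compound 3 is therefore expected at 3 nM, within a range from 0.7 nM to 15 nM.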

Compound 3, half-maximal inhibitory concentration: 2500 nM
The estimate for compound 3 lay 830-fold (2.92 log units) below the measured number; measured number outside the range, above it.
By their numbers in this assay, from the lowest: compound 1; then compound 2; then compound 3.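

In this assay, among the compounds shown here, acetyl in place of chloro on this aromatic carbon gives a 3100-fold higher number from compound 1 to compound 3 (3.49 log units; beyond the scatter), the first direct step at this position. The position therefore does not accept every replacement for chloro: one chlorine atom gives way to three heavy atoms, including a carbonyl oxygen that counts as a hydrogen-bond acceptor, and the low number of compound 1 is lost. No evidence is available to explain this loss.

The compounds shown leave open whether the carbonyl, the added methyl of the acetyl or the absence of chlorine accounts for the step. A fluoro, a nitrile or a methoxy group on the same aromatic carbon of the core of compound 1 would help separate these possibilities.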